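The source may hold more compounds than are shown below. What is called first, only, known or untested is meant among the compounds shown, and "the series" means these compounds.

Series notes. The measurements come from a functional assay on SNB-75 cells (Homo sapiens) for inhibition; on this read-out lower numbers stand for stronger inhibition of growth and higher numbers for weaker inhibition of growth. Compound 1 `C=C1CCCC(C)(C)C1CC[C@]1(C)CC[C@@H]([C@@H](C)C(=O)O)OO1` returns only a limit there: compound 1 gives > 10000 nM, which is the limit of > 10000 nM in this assay, at which 1 of the 3 values shown sits, and not a number. Compound 2 `C=C1CCCC(C)(C)C1(O)CC/C(C)=C/CC[C@]1(C)CC[C@@H]([C@@H](C)C(=O)OC)OO1` gives 15000 nM. Compound 3 `CC1=C(CC/C(C)=C/CC[C@@]2(C)CC[C@@H]([C@H](C)C(=O)O)OO2)C(C)(C)CCC1` likewise returns a limit: compound 3 gives > 100000 nM, which is the limit of > 100000 nM in this assay, at which 1 of the 3 values shown sits, and not a number. So compound 1 stands at a limit, as does compound 3, and the one real number in the set, that of compound 2, lies close to where the limit of compound 1 sits. Among the compounds with values here, no step between measured compounds is defined, since no two of them differ in a single place.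

Compound 4 `C=C1CCCC(C)(C)C1CC[C@@]1(C)CC[C@H]([C@@H](C)C(=O)O)OO1` is the next step. From compound 1 to compound 4 the change is the two compounds have the same atoms and bonds; at least one stereo element is drawn with a configuration in one of them and without one in the other: 2 of 4 stereo elements differ; a stereocentre at a saturated ring carbon is drawn R in compound 1 and S in compound 4; a stereocentre at a saturated ring carbon is drawn S in compound 1 and R in compound 4. Within the data shown here, no measured pair shows what such a change at two stereocentres does in this assay, so the size of the step cannot be read from these data; with compound 1 already at a limit, nothing beyond the usual scatter is expected in either direction. Compound 4 is therefore expected at 15000 nM in this assay, between 5000 nM and 50000 nM, which corresponds to an expected step that the limit leaves unreadable from compound 1 to compound 4.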

Compound 4, concentration for 50% growth inhibition: 3390 nM
For compound 4 the middle estimate is 4.4-fold (0.65 log units) above the measured one; the measured number lies below the stated range.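

In this assay, within the data shown here, the exchange of configuration at the two saturated ring stereocentres, with atoms and bonds unchanged, gives an at least 2.9-fold lower number from compound 1 to compound 4 (0.46 log units; beyond the scatter), so this is the first pair to show that the drawn configuration at these two stereocentres alone moves the read-out beyond the scatter. Compound 1 gives > 10000 nM, which is a limit of the assay and not a number. The true size of the step therefore remains unknown, and only its lower bound can be read, with the reading resting on this limit: the limit of > 10000 nM in this assay, at which 1 of the 4 values shown sits.

The compounds shown leave open whether one of the two saturated ring stereocentres alone carries the step or both are needed, since the two change together in this pair. Also open, on these data alone, is whether the same configuration holds its effect once the carboxylic acid on the core of compound 4 gives way to a methyl ester, an amide or a primary alcohol.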